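From Butylamino to 2-(2-Methoxyethoxy)ethoxy on a Carbonyl Carbon

The source may report more compounds than this note shows. Statements on the series, on what has been measured and on what is new or still open speak of the compounds shown alone.

Measured so far:
compound 1 `CCCCNC(=O)Nc1cc2nc(C3CCCCC3)[nH]c2cc1N(CC)CC`: > 100 ug/mL
compound 2 `COc1ccc(C(=O)Nc2cc3nc(C4CCCCC4)[nH]c3cc2N(C)C)cc1`: > 100 ug/mL
compound 3 `O=C(Nc1cc2nc(C3CCCCC3)[nH]c2cc1N1CCCC1)c1ccc(Br)cc1`: > 100 ug/mL

All three readings come from an ADME assay on Vero cells (Chlorocebus sabaeus) for cytotoxicity, read by resazurin assay, with a stated time of 3 days; on this read-out lower numbers stand for stronger inhibition and higher numbers for weaker inhibition. For compound 1 the reading > 100 ug/mL is a limit of the assay rather than a number. The same holds for compound 2 and for compound 3, whose readings are also limits. So compound 1 cannot be placed above or below its two companions; all that is known is the limit of > 100 ug/mL in this assay, at which 3 of the 3 values shown sit, and nothing separates the three.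

The new compound is compound 4 `CCN(CC)c1cc2[nH]c(C3CCCCC3)nc2cc1NC(=O)OCCOCCOC`. It differs from compound 1 in one place: 2-(2-methoxyethoxy)ethoxy in place of butylamino on a carbonyl carbon. The rest of the shared core, including the cyclohexyl group and the diethylamino group, stays as it is.

Within the data shown here, with no measured step to lean on, the expectation rests only on the three limits already seen. Because (the limit of > 100 ug/mL in this assay, at which 3 of the 3 values shown sit), a change at the carbonyl carbon of this size is not expected to bring cytotoxicity into the measurable range, so the step that the limit leaves unreadable from compound 1 to compound 4 is expected to be none beyond the scatter. For compound 4 the estimated reading in this assay is 150 ug/mL, within a range from 60 ug/mL to 400 ug/mL.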

Compound 4, half-maximal inhibitory concentration: > 100 ug/mL
Compound 4: no number, only a limit; the forecaster's own chance of this, stated with the estimate: 80%; the middle value lies beyond the limit too.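

Among these compounds, compound 1 and compound 4 both give only a limit rather than a number, so no step between them can be read. The compounds shown leave open whether 2-(2-methoxyethoxy)ethoxy in place of butylamino on a carbonyl carbon changes the reading at all in this assay, and the four compounds remain unseparated: the limit of > 100 ug/mL in this assay, at which 4 of the 4 values shown sit.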